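From naphthalen-1-yl to 3-fluorophenyl at compound 2

The source may hold more compounds than are shown below. What is called first, only, known or untested is meant among the compounds shown, and "the series" means these compounds.

In a functional assay on RS4-11 cells (Homo sapiens) for inhibition, read by CCK-8 assay, with a stated time of 48 h, tested at 20 uM (on this read-out lower numbers stand for less inhibition of growth and higher numbers for more inhibition of growth at the one concentration tested), compound 1 (`N#C/C(=C\c1ccccc1OS(=O)(=O)c1ccc([N+](=O)[O-])cc1)C(=O)Nc1nnc(Cc2cccc3ccccc23)s1`) gives 58% and compound 2 (`N#C/C(=C\c1ccccc1OS(=O)(=O)c1ccccc1[N+](=O)[O-])C(=O)Nc1nnc(Cc2cccc3ccccc23)s1`) gives 66%, so these two values lie within the scatter of each other. Within the data shown here, the only measured step is a number 8 percentage points higher from compound 1 to compound 2 (within the scatter), with 2-nitrophenyl in place of 4-nitrophenyl on a sulfonyl sulfur.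

Compound 3 (`N#C/C(=C\c1ccccc1OS(=O)(=O)c1ccccc1[N+](=O)[O-])C(=O)Nc1nnc(Cc2cccc(F)c2)s1`) keeps the 2-nitrophenyl group and differs at the other end of the molecule: 3-fluorophenyl in place of naphthalen-1-yl on a saturated chain carbon bound to an aromatic carbon. This places 3-fluorophenyl in place of naphthalen-1-yl on a saturated chain carbon bound to an aromatic carbon. Among the measured compounds shown here, no measured step touches this place, so the one step available says nothing direct about its size or direction. The starting point is therefore compound 2 at 66%, with a modest downward allowance and a wide range. In this assay, the estimated step is a number 8 percentage points lower from compound 2 to compound 3 (within the scatter), which is expected to be no larger than the scatter. For compound 3 the expected value is 58%, with an estimated range of 38% to 76%.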

Compound 3, percent growth inhibition at one concentration: 68%
For compound 3 the middle estimate is 10 percentage points below the measured one, and the stated range covers the measured number.
By their numbers in this assay, from the lowest: compounds 1, 2 and 3 (each within the scatter of the next).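

Among these compounds, the earlier step concerned only the nitrophenyl group on the sulfonyl sulfur, so this is the first reading at the other end of the molecule. In this assay the change gives a number 2 percentage points higher from compound 2 to compound 3 (within the scatter), with 3-fluorophenyl in place of naphthalen-1-yl on a saturated chain carbon bound to an aromatic carbon. At the one concentration tested, this read-out therefore does not separate the group of 10 heavy atoms and 2 six-membered aromatic rings from the group of 7 heavy atoms and one such ring, so this place accepts either group without a difference beyond the scatter, and nothing available explains that result.

Both groups shown at this place carry an aromatic ring of carbon only, so it remains open whether the read-out would hold with plain phenyl, or with a ring-free group such as a carboxylic acid, a dimethylamino group or a longer alkyl chain. From the compounds shown here alone, it also remains open whether compound 2 and compound 3 would stay together over a range of concentrations, since a single concentration cannot show that.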